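Urea analogues at the aorta: a pyridyl swap

The compounds below may be only part of what the source reports. "The series", "measured", "known", "first", "only" and "open" are said of these compounds alone.

Measured so far:
compound 1, `CC1(C)Oc2ccc(C#N)cc2[C@@H](/N=C(\NC#N)Nc2ccccc2)[C@@H]1O`, 1400000 nM
compound 2, `CC(C)(C)c1ccc(C#N)cc1NC(=O)Nc1ccncc1`, 7800000 nM

In a functional assay (aorta) for inhibition, with Rattus norvegicus as the target (a higher number here means a weaker inhibitor, a lower number a stronger inhibitor), compound 2 gives the higher of the two numbers, and its gap to compound 1 is beyond the scatter. Compound 3, `CC(C)(C)c1ccc(C#N)cc1NC(=O)Nc1ccc(Cl)nc1`, is not yet measured. It differs from compound 2 in one place: 6-chloropyridin-3-yl in place of pyridin-4-yl on an amide-type nitrogen. Among the measured compounds shown here, no measured pair shows what such a change does here, so no step beyond the scatter is expected, in either direction, from compound 2 to compound 3 (a 1.3-fold lower number from compound 2 to compound 3 (0.11 log units; within the scatter)). Compound 3 is therefore estimated at 6000000 nM, with a range from 2000000 nM to 20000000 nM.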

Compound 3, half-maximal inhibitory concentration: 1600000 nM
The estimate for compound 3 lay 3.8-fold (0.57 log units) above the measured number; measured number outside the range, below it.
By their numbers in this assay, from the lowest: compounds 1 and 3 (each within the scatter of the next); then compound 2.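

In this assay, the amide-type nitrogen proves responsive to the aromatic group it carries: 6-chloropyridin-3-yl in place of pyridin-4-yl gives a 4.9-fold lower number from compound 2 to compound 3 (0.69 log units; beyond the scatter). This single pair changes the ring attachment and adds the chlorine together, so their contributions cannot be separated. Nothing available explains the step. As far as these compounds go, what pyridin-3-yl without the chlorine would give on this nitrogen remains open, as does the outcome with 6-methoxypyridin-3-yl. Whether any such group would go further in the same direction is also unknown.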